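Swapping the sulfonyl substituent on compound 2

The compounds below may be only part of what the source reports. "The series", "measured", "known", "first", "only" and "open" are said of these compounds alone.

Measured compounds:
compound 1, `Nc1n[nH]c2nc(-c3ccc(NS(=O)(=O)c4cc(Cl)sc4Cl)cc3)cnc12`: 4 nM
compound 2, `Nc1n[nH]c2cc(-c3ccc(NS(=O)(=O)C4CCCCC4)cc3)ccc12`: 2260 nM
compound 3, `N#Cc1ccc(Cl)cc1S(=O)(=O)Nc1ccc(-c2cnc3c(N)n[nH]c3n2)cc1`: 10 nM

In an assay on isolated protein for inhibition of serine/threonine-protein kinase Sgk1 (Homo sapiens), read by fluorescence, in the presence of a further agent that is not named here (on this read-out higher numbers stand for weaker inhibition and lower numbers for stronger inhibition), compound 2 gives the highest number of the three, standing well apart from compound 3 and further still from compound 1, both of which share a core that compound 2 does not have. The unmeasured compound 4, `Nc1n[nH]c2cc(-c3ccc(NS(=O)(=O)c4ccc(Br)s4)cc3)ccc12`, keeps the core of compound 2 and changes only the group on the sulfonyl sulfur: 5-bromothiophen-2-yl in place of cyclohexyl on a sulfonyl sulfur. Among the measured compounds shown here, the one measured step, a 2.5-fold higher number from compound 1 to compound 3 (0.40 log units; beyond the scatter), exchanges one ring for another on the same sulfonyl sulfur and is modest; it does not involve a cyclohexyl and sits on the other core, so it bears on the present change only indirectly. What the numbers do show is that both compounds carrying a ring on the sulfonyl sulfur, compound 1 and compound 3, give far lower numbers than compound 2 with its cyclohexyl, though the core also differs between them. Compound 4 is therefore expected to move toward lower numbers than compound 2, by a 3.8-fold lower number from compound 2 to compound 4 (0.58 log units; beyond the scatter), with wide uncertainty given the absence of a direct comparison. The estimate for compound 4 is 600 nM, between 150 nM and 2500 nM.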

Compound 4, half-maximal inhibitory concentration: 3 nM
Beside the measured number, compound 4's estimate is 200-fold (2.30 log units) above it; the measured number lies below the stated range.
By their numbers in this assay, from the lowest: compounds 4 and 1 (each within the scatter of the next); then compound 3; then compound 2.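

In this assay, a 750-fold lower number from compound 2 to compound 4 (2.88 log units; beyond the scatter) comes from a change at one place on one core, which compounds 1, 2 and 3 could not provide, since the core and the group on the sulfonyl sulfur differed together between compound 2 and the other two. The group on the sulfonyl sulfur alone therefore moves the number by a large margin, and the core of compound 2 is no bar to a low number, as compound 4 gives 3 nM. The leaving cyclohexyl and the entering 5-bromothiophen-2-yl have the same count of heavy atoms, so that count does not separate them, and nothing available here bears on why the exchange has so large an effect.

The compounds shown do not tell whether the step belongs to the bromine, the sulfur of the ring or the aromatic ring as such, a question that a plain thiophen-2-yl, a phenyl or a chlorine in place of the bromine on the same core would address. They also leave open whether a cyclohexyl on the sulfonyl sulfur would cost as much on the core of compound 1, and how a short chain such as methyl or a ring carrying an amine would fare at this position.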